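Series notes: bromo to methoxy on the benzyl ring

The compounds below may be only part of what the source reports. "The series", "measured", "known", "first", "only" and "open" are said of these compounds alone.

The three measured compounds share one core and differ only in the group on the sulfur. Compound 1 `C#CCSc1nc2cc(Cl)c(Cl)cc2n1C1O[C@H](CO)[C@@H](O)[C@H]1O` gives 60000 nM in a functional assay on KB cells (Homo sapiens) for inhibition; a higher number here means a weaker inhibitor, a lower number a stronger inhibitor; compound 2 `C=CCSc1nc2cc(Cl)c(Cl)cc2n1C1O[C@H](CO)[C@@H](O)[C@H]1O` gives 68000 nM in this assay; compound 3 `OC[C@H]1OC(n2c(SCc3ccc(Br)cc3)nc3cc(Cl)c(Cl)cc32)[C@H](O)[C@@H]1O` gives 20000 nM in this assay. Compound 3 has the lowest number of the three: the steps of a 3.0-fold lower number from compound 1 to compound 3 (0.48 log units; beyond the scatter) and a 3.4-fold lower number from compound 2 to compound 3 (0.53 log units; beyond the scatter) both lie beyond the scatter, whereas a 1.1-fold higher number from compound 1 to compound 2 (0.05 log units; within the scatter) does not.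

Compound 4 `COc1ccc(CSc2nc3cc(Cl)c(Cl)cc3n2C2O[C@H](CO)[C@@H](O)[C@H]2O)cc1` differs from compound 3 by methoxy in place of bromo on an aromatic carbon. Within the data shown here, no measured step touches that position. The two steps beyond the scatter, a 3.0-fold lower number from compound 1 to compound 3 (0.48 log units; beyond the scatter) and a 3.4-fold lower number from compound 2 to compound 3 (0.53 log units; beyond the scatter), concern replacing a short unsaturated chain by the 4-bromophenyl group, not the substituent on that ring. They show only that this kind of benzyl sulfanyl arm gives a lower number than the short chains. For a change confined to one substituent on the ring, no step beyond the scatter is expected in this assay, in either direction. Compound 4 is therefore expected near 20000 nM, with a range from 8000 nM to 50000 nM. The expected step is no change at the digits printed from compound 3 to compound 4 (within the scatter).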

Compound 4, half-maximal inhibitory concentration: 41000 nM
The estimate for compound 4 lay 2.1-fold (0.31 log units) below the measured number, within the range that was stated.
By their numbers in this assay, from the lowest: compound 3; then compounds 4, 1 and 2 (each within the scatter of the next).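

Among these compounds, the substituent on this ring carbon does matter in this assay: methoxy in place of bromo gives a 2.1-fold higher number from compound 3 to compound 4 (0.31 log units; beyond the scatter), a step beyond the scatter that no earlier pair could show. The benzyl sulfanyl arm alone therefore does not set the number: a 1.7-fold lower number from compound 2 to compound 4 (0.22 log units; within the scatter) and a 1.5-fold lower number from compound 1 to compound 4 (0.17 log units; within the scatter) both lie within the scatter, so the 4-methoxybenzyl arm is not separated from the short chains, whereas the 4-bromobenzyl arm is. Nothing available explains the difference between bromo and methoxy at this position.

With only these two ring substituents, no trend across this position can be drawn. As far as these compounds go, whether chloro, an amine or a carboxylic acid on the same ring carbon would track bromo or methoxy remains open.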